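Swapping an amine for an alkyl chain on a diaryl core

The compounds below may be only part of what the source reports. "The series", "measured", "known", "first", "only" and "open" are said of these compounds alone.

Measured so far:
Compound 1, `CCc1nc(-c2ccc(Cl)cc2Cl)c(CC)nc1NC(CC)CC`: 0.283 h
Compound 2, `CCOc1nc(-c2ccc(Cl)cc2Cl)c(CC)nc1NC(CC)CC`: 2 h
Compound 3, `CCc1nc(-c2ccc(Cl)cc2Cl)c(OC)nc1NC(CC)CC`: 0.7 h

In an in vitro ADME assay on microsomes (Homo sapiens) for metabolic stability (a higher number here means that the compound lasts longer, a lower number that the compound disappears faster), compound 1 gives the lowest of the three numbers. Its nearest neighbour is compound 3, with a 2.5-fold higher number from compound 1 to compound 3 (0.39 log units; beyond the scatter), and the furthest is compound 2, with a 7.1-fold higher number from compound 1 to compound 2 (0.85 log units; beyond the scatter). Both of those steps exchange an ethyl group for an alkoxy group on the shared core.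

Compound 4, `CCc1nc(-c2ccc(Cl)cc2Cl)c(CC)nc1CC(CC)CC`, is not yet measured in this assay. It differs from compound 1 at a different site: 2-ethylbutyl in place of (pentan-3-yl)amino on an aromatic carbon. The group that leaves carries a nitrogen with one hydrogen-bond donor and one acceptor; the group that enters is carbon only.

Neither measured step touches this position, so they do not bear on the change directly; they only show that single changes on this core can move the half-life by a modest amount. With nothing pointing in either direction, compound 4 is expected to stay close to compound 1, the estimated step being a 1.1-fold higher number from compound 1 to compound 4 (0.03 log units; within the scatter), which lies within the usual scatter. The estimate for compound 4 is therefore 0.3 h, with a range from 0.1 h to 0.9 h.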

Compound 4, half-life: 0.217 h
The estimate for compound 4 lay 1.4-fold (0.14 log units) above the measured number; measured number inside the range.
By their numbers in this assay, from the lowest: compounds 4 and 1 (each within the scatter of the next); then compound 3; then compound 2.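

In this assay, putting 2-ethylbutyl in place of (pentan-3-yl)amino gives a 1.3-fold lower number from compound 1 to compound 4 (0.12 log units; within the scatter), so the two compounds cannot be told apart in this measurement. The earlier steps shown here exchanged an ethyl group for an alkoxy group and moved the half-life beyond the scatter, whereas this step, at the site para to the 2,4-dichlorophenyl group, shows that a carbon-only chain can take the place of the amine, with its hydrogen-bond donor and acceptor, and leave the half-life within the scatter of compound 1. No supporting data are available to explain this outcome.

The compounds shown leave open whether a different group at this site, such as a primary amine, a shorter chain or a carboxylic acid, would move the half-life beyond the scatter. They also leave open whether 2-ethylbutyl would give a similar result in the alkoxy-bearing settings of compound 2 and compound 3, where the half-life is already longer than in compound 1.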